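This account rests on a few compounds, and the source may have more. Where it says the series, first, only, none or still open, it means among the compounds named here.

Three compounds have been measured in an assay on mitochondria from L6 cells (Rattus norvegicus) for activation, with a stated time of 90 min; a lower number here means that less compound is needed, a higher number that more compound is needed for the effect:

compound 1, `Oc1nc2nonc2nc1Nc1cccc(C(F)(F)F)c1`, with 13300 nM;
compound 2, `Oc1nc2nonc2nc1Nc1ccc(C(F)(F)F)cc1`, with 10400 nM;
compound 3, `Oc1nc2nonc2nc1Nc1cc(C(F)(F)F)ccc1F`, with 5100 nM.

Compound 1 and compound 2 are built from the same atoms joined differently; the difference between the two cores is not broken down here, and their two values lie within the usual scatter of each other. Compound 3 comes from compound 1 by the change (fluoro in place of hydrogen on an aromatic carbon), and that change gave a 2.6-fold lower number from compound 1 to compound 3 (0.42 log units; beyond the scatter).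

Compound 4, `Oc1nc2nonc2nc1Nc1ccc(C(F)(F)F)c(F)c1`, is not yet measured. It comes from compound 2 by the change (fluoro in place of hydrogen on an aromatic carbon). Among the compounds with values here, this is the same kind of change as the one from compound 1 to compound 3, not the same: in compound 3 the entering fluoro sits ortho to a large group and para to a trifluoromethyl group, whereas in compound 4 it sits ortho to a trifluoromethyl group and meta to a large group. Resting on compound 2 at 10400 nM and on the step of a 2.6-fold lower number from compound 1 to compound 3 (0.42 log units; beyond the scatter), a step of about a 1.6-fold lower number from compound 2 to compound 4 (0.20 log units; within the scatter) is expected. That expected step is held smaller than the measured one, the surroundings of the place being different. Compound 4 is therefore estimated at 6500 nM in this assay, within 2500 nM to 15000 nM.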

Compound 4, half-maximal effective concentration: 11600 nM
The estimate for compound 4 lay 1.8-fold (0.25 log units) below the measured number; the range from low to high includes it.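

In this assay, fluoro in place of hydrogen on an aromatic carbon gave a 1.1-fold higher number from compound 2 to compound 4 (0.05 log units; within the scatter), so the effect seen on the core of compound 1 did not carry over to the core of compound 2, and the two steps differ: the same change on two cores in this assay, a 2.6-fold lower number (0.42 log units; beyond the scatter) from compound 1 to compound 3 and a 1.1-fold higher number (0.05 log units; within the scatter) from compound 2 to compound 4, 2.9-fold (0.46 log units) apart, beyond the scatter of two such steps

This shows that, in this series, the size of the step from this change cannot simply be transferred from one core to the other. It does not show what sets the two steps apart, since the trifluoromethyl group and the entering fluoro both stand at different places in the two pairs, and two pairs are too few to separate these or to give a rule for other cores.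

The compounds shown leave open whether chloro, methyl or methoxy at the place taken by fluoro in compound 4 would also leave the number close to that of compound 2. They also leave open how an amine or a carboxylic acid at that place would fare.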